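The compounds below may be only part of what the source reports. "The series", "measured", "known", "first", "only" and "open" are said of these compounds alone.

Compound 1 `Cc1ccccc1Cc1cnc(CCc2ccc(-c3ccccc3C(=O)O)cc2)[nH]1` gives 127 nM; compound 2 `COc1cccc(Cc2cnc(CCc3ccc(-c4ccccc4C(=O)O)cc3)[nH]2)c1` gives 4120 nM.

In an in vitro functional assay on cells for agonist activity at Bombesin receptor subtype-3 (Homo sapiens), read by luminescence and calcium flux (on this read-out higher numbers stand for an effect only at larger amounts of compound and lower numbers for an effect already at smaller amounts), compound 2 stands with the higher of the two numbers. For the measured compounds named here, the only measured step that bears on the change ahead is a 32-fold higher number from compound 1 to compound 2 (1.51 log units; beyond the scatter), where 3-methoxyphenyl replaced 2-methylphenyl. Compound 3 `O=C(O)c1ccccc1-c1ccc(CCc2ncc(Cc3ccccc3F)[nH]2)cc1` swaps that group again: 2-fluorophenyl in place of 3-methoxyphenyl on a saturated chain carbon bound to an aromatic carbon. The 2-fluorophenyl resembles the 2-methylphenyl of compound 1 more than the 3-methoxyphenyl does, and because a 32-fold higher number from compound 1 to compound 2 (1.51 log units; beyond the scatter) was large, compound 3 is expected to move back a good part of the way, an estimated 16-fold lower number from compound 2 to compound 3 (1.22 log units; beyond the scatter). Compound 3 is therefore expected near 250 nM, within 60 nM to 1000 nM.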

Compound 3, half-maximal effective concentration: 177 nM
Compound 3: middle estimate off by 1.4-fold (0.15 log units), on the high side, within the range that was stated.
By their numbers in this assay, from the lowest: compounds 1 and 3 (each within the scatter of the next); then compound 2.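

The 2-fluorophenyl group undoes the large loss seen with 3-methoxyphenyl on this saturated chain carbon (a 23-fold lower number from compound 2 to compound 3 (1.37 log units; beyond the scatter)). It also matches the 2-methylphenyl group, since the numbers do not separate (a 1.4-fold higher number from compound 1 to compound 3 (0.14 log units; within the scatter)), so two different groups named as 2-substituted phenyls now sit together, with the 3-methoxyphenyl compound apart. No measurement here explains why these groups differ.

The 3-methoxyphenyl group differs from the other two in both its substituent and that substituent's place on the ring, and these two changes cannot be separated. A 2-methoxyphenyl or 3-fluorophenyl group would be needed to tell which one matters.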